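Replacing the methyl group of compound 3 with hydrogen

This account rests on a few compounds, and the source may have more. Where it says the series, first, only, none or still open, it means among the compounds named here.

Compound 1 `COc1ccc(-c2cc(=O)oc3ccc(Cl)cc23)cc1O`: 40000 nM
Compound 2 `COc1ccc(-c2cc(=O)oc3ccc(F)cc23)cc1O`: 80000 nM
Compound 3 `COc1ccc(-c2cc(=O)oc3ccc(C)cc23)cc1O`: 40000 nM

All three numbers come from a physicochemical assay for solubility, in phosphate buffer, with a stated time of 2 h, at pH 7.4; a higher number here means a more soluble compound, a lower number a less soluble compound. The compounds share one core and differ in a single group on an aromatic carbon: chloro, fluoro or methyl. Compound 3 stands level with compound 1, and its gap to compound 2 lies within the scatter.

The next compound is compound 4 `COc1ccc(-c2cc(=O)oc3ccccc23)cc1O`, which has hydrogen in place of methyl on an aromatic carbon.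

The most relevant evidence comes from the three swaps among the measured compounds. Fluoro in place of chloro gives a 2.0-fold higher number from compound 1 to compound 2 (0.30 log units; within the scatter). Methyl in place of chloro gives no change at the digits printed from compound 1 to compound 3 (within the scatter). Methyl in place of fluoro gives a 2.0-fold lower number from compound 2 to compound 3 (0.30 log units; within the scatter). Among the measured compounds shown here, none of these steps goes beyond the scatter, although no measured compound carries hydrogen at this place, so the change itself remains untested. A step beyond the scatter is therefore not expected in this assay, and the starting point is compound 3 at 40000 nM.

The expected step is a 1.3-fold higher number from compound 3 to compound 4 (0.10 log units; within the scatter).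

For compound 4 the estimated value is 50000 nM, with an expected range from 25000 nM to 100000 nM.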

Compound 4, solubility: 160000 nM
Beside the measured number, compound 4's estimate is 3.2-fold (0.51 log units) below it; the whole stated range lies below it.
By their numbers in this assay, from the lowest: compounds 1, 3, 2 and 4 (each within the scatter of the next, the first and the last beyond it).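

In this assay, this position now shows a step beyond the scatter: swaps among chloro, fluoro and methyl all stayed within it, whereas hydrogen on this aromatic carbon gives a 4.0-fold higher number from compound 3 to compound 4 (0.60 log units; beyond the scatter) and a 4.0-fold higher number from compound 1 to compound 4 (0.60 log units; beyond the scatter). Fluoro goes against any simple split between hydrogen and the three groups, since hydrogen in its place gives a 2.0-fold higher number from compound 2 to compound 4 (0.30 log units; within the scatter), so compound 2 and compound 4 cannot be told apart in this assay. The result therefore separates hydrogen from methyl and from chloro, but not from fluoro, and no measurement at hand offers an explanation for this.

The compounds shown leave open how the number would respond to quite different groups on this aromatic carbon, such as an amine, a carboxylic acid or a longer alkyl chain. As far as these compounds go, it also remains open whether hydrogen in place of methyl or chloro would give a step of similar size on a different core.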